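The compounds below may be only part of what the source reports. "The series", "measured", "known", "first", "only" and "open" are said of these compounds alone.

Measured compounds:
- compound 1, `Cc1cc(NC(=O)Cn2nnc(-c3ccccc3)n2)n(C2CCCCC2)n1`: 92%
- compound 2, `Cc1cc(NC(=O)Cn2nnc(-c3ccccc3)n2)n(-c2ccccc2)n1`: 66%

In an assay on HEK293 cells for activation of Kir3.1/Kir3.2 (Homo sapiens), read by thallium flux (on this read-out higher numbers stand for larger maximal responses and lower numbers for smaller maximal responses), compound 1 gives 92%, the higher of the two numbers recorded, while compound 2 gives 66%. For the measured compounds named here, the one measured step, a number 26 percentage points lower from compound 1 to compound 2 (beyond the scatter), concerns a change on an aromatic nitrogen of the shared core and is of modest size.

Compound 3, `Cc1cc(NC(=O)Cn2nnc(-c3ccc(Cl)c(Cl)c3)n2)n(C2CCCCC2)n1`, differs from compound 1 in another place: 3,4-dichlorophenyl in place of phenyl on an aromatic carbon. Going by the values given here, no measured step touches this position, so the step from compound 1 to compound 2 offers no direct guide here; it only shows that a single change at the edge of this core can shift the maximal response by a modest amount. With nothing pointing to a direction, the expected step for compound 3 is a number 4 percentage points lower from compound 1 to compound 3 (within the scatter), within the scatter. Compound 3 is therefore estimated to give 88%, with a range from 65% to 105%.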

Compound 3, largest response reached (Emax), in percent of the reference or control that the assay uses: 84%
Compound 3: the middle estimate sits 4 percentage points above what was measured; the measured number falls inside the stated range.
By their numbers in this assay, from the lowest: compound 2; then compounds 3 and 1 (each within the scatter of the next).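

Swapping phenyl for 3,4-dichlorophenyl on the aromatic carbon of the five-membered aromatic ring with 4 nitrogen gives a number 8 percentage points lower from compound 1 to compound 3 (within the scatter) in this assay, so this read-out does not separate the two compounds. For the compounds shown here, this is the first measured change at this position, and it shows that adding two chlorine atoms to the phenyl ring leaves the maximal response within the usual spread of repeated measurements. The data shown offer no measured explanation for this result.

As far as these compounds go, whether the response would hold with a single chlorine, or with a quite different group here such as a methoxy, an amine or a carboxylic acid, stays open. Also open, from the compounds shown here alone, is whether 3,4-dichlorophenyl would give a similar step on a core carrying phenyl instead of cyclohexyl on the aromatic nitrogen.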